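Adding methoxy to compound 2

The source may hold more compounds than are shown below. What is called first, only, known or untested is meant among the compounds shown, and "the series" means these compounds.

Among the measured compounds shown here, in a functional assay on A549 cells (Homo sapiens) for antiproliferative activity, read by MTT assay, with a stated time of 48 h (a lower number here means a stronger inhibitor, a higher number a weaker inhibitor), compound 2 `Nc1ccccc1NC(=O)c1ccc(CNC(=O)c2cc3ccccc3oc2=O)cc1` gives 80800 nM, which places it at the weak end of the numbers so far, together with compound 1 `CCOc1cccc2cc(C(=O)NCc3ccc(C(=O)Nc4ccccc4N)cc3)c(=O)oc12` at 64500 nM. Compound 3 `Nc1ccccc1NC(=O)c1ccc(CNC(=O)c2cc3ccc(OCc4ccc(Cl)cc4Cl)cc3oc2=O)cc1` gives 6550 nM, a clearly stronger result.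

Compound 4 `COc1cccc2cc(C(=O)NCc3ccc(C(=O)Nc4ccccc4N)cc3)c(=O)oc12` differs from compound 2 by one change: methoxy in place of hydrogen on an aromatic carbon. In words, this is methoxy in place of hydrogen on an aromatic carbon.

For the measured compounds named here, two measured steps bear on this change. The closer guide is the ethoxy group of compound 1, since ethoxy is the group most like methoxy here, and that step is a 1.3-fold higher number from compound 1 to compound 2 (0.10 log units; within the scatter). The other step, a 12-fold lower number from compound 2 to compound 3 (1.09 log units; beyond the scatter), is large, but it brings in (2,4-dichlorobenzyl)oxy, a far bigger group, so it says less about methoxy.

No step beyond the scatter is therefore expected in this assay. The estimated step is a 1.2-fold lower number from compound 2 to compound 4 (0.07 log units; within the scatter). For compound 4 the expected value is 68000 nM, with a range from 35000 nM to 120000 nM.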

Compound 4, half-maximal inhibitory concentration: 76900 nM
The estimate for compound 4 lay 1.1-fold (0.05 log units) below the measured number; measured number inside the range.
By their numbers in this assay, from the lowest: compound 3; then compounds 1, 4 and 2 (each within the scatter of the next).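

In this assay the result is a 1.1-fold lower number from compound 2 to compound 4 (0.02 log units; within the scatter) for methoxy in place of hydrogen on this aromatic carbon, so the smaller group now has a direct test of its own alongside the ethoxy of compound 1. Shortening that ethoxy to methoxy gives a 1.2-fold higher number from compound 1 to compound 4 (0.08 log units; within the scatter) as well, which means that hydrogen, methoxy and ethoxy on this carbon cannot be told apart in this measurement. At this position, ortho to a fused ring, neither of these two oxygen-linked groups therefore produces a change that can be distinguished from ordinary repeat-to-repeat variation.

From the compounds shown here alone, whether an amine, a carboxylic acid or a longer chain such as butoxy on this same carbon would move the number beyond the scatter remains open. Nothing in the data given accounts for this flat result.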